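The compounds below may be only part of what the source reports. "The series", "measured", "known", "first", "only" and "open" are said of these compounds alone.

Going by the values given here, in a functional assay on PC-3 cells (Homo sapiens) for cytotoxicity, read by MTT assay, with a stated time of 24 h (a lower number here means a stronger inhibitor, a higher number a weaker inhibitor), compound 1 `O=C1/C(=C/c2ccccc2F)CN(Cc2cn(Cc3cccc(Cl)c3)nn2)C/C1=C\c1ccccc1F` gives 6800 nM and holds the lower of the two numbers so far. Compound 2 `COc1ccc(/C=C2\CN(Cc3cn(Cc4ccccc4Cl)nn3)C/C(=C\c3ccc(OC)cc3)C2=O)cc1` gives 36300 nM and the gap between the two lies beyond the scatter. These two compounds differ in more than one place, so the gap does not isolate any single change.

Compound 3 `O=C1/C(=C/c2ccccc2F)CN(Cc2cn(Cc3ccc(F)cc3)nn2)C/C1=C\c1ccccc1F` differs from compound 1 by one change 4-fluorophenyl in place of 3-chlorophenyl on a saturated chain carbon bound to an aromatic nitrogen that puts 4-fluorophenyl in place of 3-chlorophenyl on a saturated chain carbon bound to an aromatic nitrogen. Among the compounds with values here, no measured pair tests this change, so the expectation is loose. A small drift toward a higher number is expected in this assay but nothing beyond the scatter. The expected step is a 1.3-fold higher number from compound 1 to compound 3 (0.12 log units; within the scatter) and it would stay within the scatter. For compound 3 the estimated value is 9000 nM with an expected range of 3000 nM to 27000 nM.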

Compound 3, half-maximal inhibitory concentration: 19400 nM
Compound 3: middle estimate off by 2.2-fold (0.33 log units), on the low side, within the range that was stated.
By their numbers in this assay, from the lowest: compound 1; then compounds 3 and 2 (each within the scatter of the next).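

In this assay, going by these compounds alone, replacing 3-chlorobenzyl with 4-fluorobenzyl while the rest of the structure stays the same gives a 2.9-fold higher number from compound 1 to compound 3 (0.46 log units; beyond the scatter), the first reading that isolates a single change. The number at this place, on a saturated chain carbon bound to an aromatic nitrogen, therefore responds to the aryl substituent, even though both groups have the same heavy-atom count and neither has hydrogen-bond donors or acceptors. No measurement at hand accounts for the step.

The step changes both the halogen and its place on the ring, and the compounds shown do not separate these two changes. From the compounds shown here alone, how an unsubstituted benzyl, or a longer chain ending in an amine, would read at this place also remains open.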